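Amide-aryl swap on the anilinopyrimidine series: compound 3 to 4

The compounds below may be only part of what the source reports. "The series", "measured", "known", "first", "only" and "open" are said of these compounds alone.

Notes on the series. Compound 1 `COc1ccc(C(=O)Nc2ccc(Cl)cn2)cc1Nc1nccc(-c2cccnc2)n1` in a functional assay on K562 cells (Homo sapiens) for antiproliferative activity, read by MTT assay, with a stated time of 48 h (on this read-out lower numbers stand for stronger inhibition and higher numbers for weaker inhibition), gives "not determined" (no result reported), and compound 2 `COc1ccc(C(=O)Nc2ncccn2)cc1Nc1nccc(-c2cccnc2)n1` gives "not determined" (no result reported); both carry pyridinyl and pyrimidinyl amides and neither has a number. Within the data shown here, compound 3 `COc1ccc(C(=O)Nc2ccncc2)cc1Nc1nccc(-c2cccnc2)n1` is the only compound with a value: in this assay compound 3 gives 94500 nM, a weak result and the sole reference point. Compound 4 `COc1ccc(C(=O)Nc2cc(Br)cc(C(F)(F)F)c2)cc1Nc1nccc(-c2cccnc2)n1` differs from it in one place: 3-bromo-5-(trifluoromethyl)phenyl in place of pyridin-4-yl on an amide-type nitrogen. Among the measured compounds shown here, no measured step exists between any two compounds, so the size of the change can only be estimated. Given the weak starting value of compound 3 at 94500 nM, the step from compound 3 to compound 4 is expected to be a marked gain in inhibition, beyond the usual scatter, at about a 32-fold lower number from compound 3 to compound 4 (1.50 log units; beyond the scatter). Compound 4 is therefore estimated at 3000 nM, with a range from 400 nM to 25000 nM.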

Compound 4, half-maximal inhibitory concentration: 215000 nM
For compound 4 the middle estimate is 72-fold (1.86 log units) below the measured one, and the stated range ends below it.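

In this assay, the place on the amide-type nitrogen now has its first readable step: 3-bromo-5-(trifluoromethyl)phenyl in place of pyridin-4-yl gives a 2.3-fold higher number from compound 3 to compound 4 (0.36 log units; beyond the scatter) and so a modest loss of inhibition. Exchanging pyridin-4-yl for this larger, carbon-only aromatic ring therefore brings no gain from an already weak starting point. Nothing available bears on the reason for this step.

Still open, going by these compounds, is whether a different kind of group in this place, such as a morpholine or a carboxylic acid, would lower the number. Two compounds alone leave any trend at this nitrogen undefined.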